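Chloro Moved From One Ring Position to Another

A few compounds are considered here, and "the series" means these few. Any claim that something is new, unique, unknown or untested is made for them only; others in the source may bear on it.

Of the compounds shown here, three built on one shared core have been measured in an assay on microsomes from brain for inhibition of Fatty-acid amide hydrolase 1 (Rattus norvegicus), read by fluorescence and HPLC, with a stated time of 60 min; a lower number here means a stronger inhibitor, a higher number a weaker inhibitor. Compound 1 `CCCCCCCCc1ccc(OCC(=O)Cn2nnc(-c3ccccc3)n2)cc1` gives 24 nM. Compound 2 `CCCCCCCCc1ccc(OCC(=O)Cn2nnc(-c3ccccc3Cl)n2)cc1` differs from it by one change, (chloro in place of hydrogen on an aromatic carbon), and in this assay compound 2 gives 32 nM; the step of a 1.3-fold higher number from compound 1 to compound 2 (0.12 log units; within the scatter). Compound 3 `CCCCCCCCc1ccc(OCC(=O)Cn2nnnc2-c2ccccc2)cc1` has the same atoms as compound 1 joined differently; the difference between the two cores is not broken down here. In this assay compound 3 gives 71 nM, the highest of the three numbers.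

Compound 4 `CCCCCCCCc1ccc(OCC(=O)Cn2nnnc2-c2ccc(Cl)cc2)cc1` is not yet measured. It differs from compound 3 by chloro in place of hydrogen on an aromatic carbon. This is the same kind of change as the one made between the first two compounds, but the surroundings of the place differ: in compound 2 the chloro sits ortho to a large group, in compound 4 it sits para to a large group. Because the measured step of a 1.3-fold higher number from compound 1 to compound 2 (0.12 log units; within the scatter) stayed within the scatter, a similarly small step is expected, a 1.1-fold higher number from compound 3 to compound 4 (0.05 log units; within the scatter). Among the compounds with values here, the core of compound 3 has no measured chloro analogue of its own, so the range is kept wide. Compound 4 is estimated at 80 nM, expected between 40 nM and 170 nM.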

Compound 4, half-maximal inhibitory concentration: 130 nM
Compound 4: the middle estimate sits 1.6-fold (0.21 log units) below what was measured; the range from low to high includes it.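

In this assay, putting a chloro on the phenyl ring of compound 3 gives a small step, a 1.8-fold higher number from compound 3 to compound 4 (0.26 log units; within the scatter). Set beside the earlier chloro step, the change carries from one core to the other with no difference that can be told apart from the ordinary spread of repeated measurements: the same change on two cores in this assay, a 1.3-fold higher number (0.12 log units; within the scatter) from compound 1 to compound 2 and a 1.8-fold higher number (0.26 log units; within the scatter) from compound 3 to compound 4, 1.4-fold (0.14 log units) apart, within the scatter of two such steps. Within the data shown here, this does not show that the two steps are truly equal or that a chloro would be tolerated on other cores: only two pairs stand here, and the chloro sits at a different ring position in each, so the effect of the core cannot be separated from the effect of the position.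

The compounds shown leave open what a chloro at the same ring position would do on both cores. They also leave open whether a fluoro group, an amine or a carboxylic acid in place of the chloro would give a step as small as these.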